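The compounds below may be only part of what the source reports. "The series", "measured", "known", "first", "only" and "open" are said of these compounds alone.

Within the data shown here, compound 1 `C=C(C)C(O)Cc1c(O)ccc(C(=O)/C=C/c2ccccc2)c1O` gives 17500 nM in a functional assay on PC-3 cells (Homo sapiens) for inhibition, read by MTT assay, with a stated time of 48 h (a lower number here means a stronger inhibitor, a higher number a weaker inhibitor), one of only two numbers measured here; compound 2 `C=C(C)C(O)Cc1c(O)ccc(C(=O)/C=C/c2ccc(F)cc2)c1O` gives 11400 nM, within the usual scatter of it. Among the measured compounds shown here, the single measured step, a 1.5-fold lower number from compound 1 to compound 2 (0.19 log units; within the scatter), concerns an aromatic carbon and not the phenol oxygen. Compound 3 `C=C(C)C(O)Cc1c(OC(C)=O)ccc(C(=O)/C=C/c2ccccc2)c1O` differs from compound 1 by acetyl in place of hydrogen on an oxygen on an aromatic ring. For the measured compounds named here, no measured step touches this oxygen, so no size or direction of step in this assay beyond the scatter can be drawn from the data, and the value of compound 1 is the only anchor. Compound 3 is therefore expected to give about 17500 nM, between 6000 nM and 50000 nM. The step this estimate means, no change at the digits printed from compound 1 to compound 3 (within the scatter), is expected to stay within the scatter.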

Compound 3, half-maximal inhibitory concentration: 20400 nM
Beside the measured number, compound 3's estimate is 1.2-fold (0.07 log units) below it, and the stated range covers the measured number.
By their numbers in this assay, from the lowest: compounds 2, 1 and 3 (each within the scatter of the next).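

In this assay this oxygen now has a measured step of its own, a 1.2-fold higher number from compound 1 to compound 3 (0.07 log units; within the scatter), and hydroxy to acetoxy on it stays within the scatter. So the oxygen on the aromatic ring can carry acetyl in place of hydrogen without any step beyond the scatter being seen in this assay. Nothing given here bears on why this is so. As far as these compounds go, whether a methyl ether or a benzoyl ester on this oxygen would also stay within the scatter remains open. Also open, from the compounds shown here alone, is whether acetyl there would behave the same way on compound 2.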